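Series notes: aryl swap on the core nitrogen, compound 4

The source may hold more compounds than are shown below. What is called first, only, known or untested is meant among the compounds shown, and "the series" means these compounds.

Three compounds of this series have been run in a functional assay on A549 cells (Homo sapiens) for antiproliferative activity, read by MTT assay, with a stated time of 72 h; on this read-out higher numbers stand for weaker inhibition and lower numbers for stronger inhibition. Compound 2 `O=C(Nc1ccc(Oc2ccnc3[nH]ccc23)c(F)c1)c1cc2cccnc2n(-c2ccc(Cl)cc2)c1=O` gives 110 nM, compound 3 `COc1ccc(-n2c(=O)c(C(=O)Nc3ccc(Oc4ccnc5[nH]ccc45)c(F)c3)cc3cccnc32)cc1` gives 610 nM, and compound 1 `O=C(Nc1ccc(Oc2ccnc3[nH]ccc23)cc1)c1cc2cccnc2n(-c2ccc(C(F)(F)F)cc2Cl)c1=O` gives 3230 nM. Compound 3 thus holds the second highest of the three numbers, with compound 1 above it and compound 2 below it. For the measured compounds named here, the one single-point step measured so far is a 5.5-fold higher number from compound 2 to compound 3 (0.74 log units; beyond the scatter); its reverse, chloro in place of methoxy, would be a step to lower numbers.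

Compound 4 `O=C(Nc1ccc(Oc2ccnc3[nH]ccc23)c(F)c1)c1cc2cccnc2n(-c2ccc(C(F)(F)F)cc2Cl)c1=O` is the next entry; the change is 2-chloro-4-(trifluoromethyl)phenyl in place of 4-methoxyphenyl on an aromatic nitrogen. Going by the values given here, the group that enters is the one carried by compound 1, which gives 3230 nM, the highest number of the three, while compound 4 keeps the fluoro of compound 3 that compound 1 lacks. Among the compounds with values here, no measured step covers that fluoro. The expectation for compound 4 in this assay therefore rests on compound 1 and is a rise, a 2.5-fold higher number from compound 3 to compound 4 (0.39 log units; beyond the scatter), with wide uncertainty. Compound 4 is estimated at 1500 nM, range 400 nM to 5000 nM.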

Compound 4, half-maximal inhibitory concentration: 1020 nM
For compound 4 the middle estimate is 1.5-fold (0.17 log units) above the measured one; measured number inside the range.
By their numbers in this assay, from the lowest: compound 2; then compounds 3 and 4 (each within the scatter of the next); then compound 1.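

In this assay, 2-chloro-4-(trifluoromethyl)phenyl in place of 4-methoxyphenyl on the aromatic nitrogen gives a 1.7-fold higher number from compound 3 to compound 4 (0.22 log units; within the scatter), so these two aryl groups are not separated at this position, while the same group in place of 4-chlorophenyl gives a 9.3-fold higher number from compound 2 to compound 4 (0.97 log units; beyond the scatter). The fluoro now has a reading of its own: with 2-chloro-4-(trifluoromethyl)phenyl held on the nitrogen, fluoro in place of hydrogen on the aromatic carbon gives a 3.2-fold lower number from compound 1 to compound 4 (0.50 log units; beyond the scatter). Nothing available explains either step.

Whether the fluoro step carries over to the 4-chlorophenyl or 4-methoxyphenyl compounds remains open, as the hydrogen counterpart is shown only with 2-chloro-4-(trifluoromethyl)phenyl. Also open, as far as these compounds go, is how an aryl group bearing an amine or a carboxylic acid, or an ethyl chain on the nitrogen, would read here.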